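This account rests on a few compounds, and the source may have more. Where it says the series, first, only, none or still open, it means among the compounds named here.

Three compounds share one core and differ only in the aryl group attached to it. Compound 1 `CCOC(=O)CCCCCOc1cccc(CN(C(=O)c2ccc(-c3cccc(N(C)C)c3)cc2)C(C)C)c1` carries a 3-(dimethylamino)phenyl group there. In an ADME assay on Raji cells (Homo sapiens) for cytotoxicity, read by CellTiter-Glo and resazurin assay, with a stated time of 72 h (a higher number here means that more compound is needed for the effect, a lower number that less compound is needed), compound 1 gives > 26000 nM, which is a limit of the assay and not a number. Compound 2 `CCOC(=O)CCCCCOc1cccc(CN(C(=O)c2ccc(-c3ccc4[nH]ccc4c3)cc2)C(C)C)c1` carries a 1H-indol-5-yl group. In this assay compound 2 gives > 26000 nM, again a limit. Compound 3 `CCOC(=O)CCCCCOc1cccc(CN(C(=O)c2ccc(-c3cccc(O)c3)cc2)C(C)C)c1` carries a 3-hydroxyphenyl group. In this assay compound 3 gives > 26000 nM, also a limit. Because all three sit at the limit of > 26000 nM in this assay, at which 3 of the 3 values shown sit, the steps among them cannot be read: a step that the two limits leave unreadable from compound 1 to compound 2, a step that the two limits leave unreadable from compound 1 to compound 3 and a step that the two limits leave unreadable from compound 2 to compound 3. Compound 3 thus stands with the others at the limit, with no number of its own. Compound 4 `CCOC(=O)CCCCCOc1cccc(CN(C(=O)c2ccc(-c3cc(F)cc(OC)c3)cc2)C(C)C)c1` is not yet measured; it differs from compound 3 by 3-fluoro-5-methoxyphenyl in place of 3-hydroxyphenyl on an aromatic carbon. All three measured steps, each a swap of the same aryl group, bear on this change, and none showed a readable size. No step beyond the scatter is therefore expected, and the step from compound 3 to compound 4 is estimated as a step that the limit leaves unreadable from compound 3 to compound 4. Compound 4 is expected to give about 40000 nM, between 15000 nM and 110000 nM, most likely again only a limit.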

Compound 4, half-maximal effective concentration: > 26000 nM
Compound 4 was reported as a limit (the forecaster's own chance of this, stated with the estimate: 85%); the middle value lies beyond the limit too.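

The steps from compound 1, compound 2 and compound 3 to compound 4 cannot be read, because all four compounds sit at one limit, which is not a number: the limit of > 26000 nM in this assay, at which 4 of the 4 values shown sit. The compounds shown leave open what concentration any of them needs in this assay and whether swapping the aryl group alters it.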